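Working notes: from allyloxy to pentyloxy

A few compounds are considered here, and "the series" means these few. Any claim that something is new, unique, unknown or untested is made for them only; others in the source may bear on it.

Measured in a functional assay on J774.A1 cells (Mus musculus) for inhibition, read by Griess assay, with stated times of 1 h and 24 h; a lower number here means a stronger inhibitor, a higher number a weaker inhibitor:
- compound 1 `CC(C)c1ccc(COc2ccccc2C2CC(=O)c3ccccc3O2)cc1`: 28600 nM
- compound 2 `C=CCOc1ccccc1C1CC(=O)c2ccccc2O1`: 38600 nM

Among the measured compounds shown here, compound 2, at 38600 nM, cannot be separated from compound 1, the only other measured member of the series, since the two values lie within the scatter of each other.

The next compound, compound 3 `CCCCCOc1ccccc1C1CC(=O)c2ccccc2O1`, has butyl in place of vinyl on a saturated chain carbon bound to an oxygen on an aromatic ring. The same difference reads as allyloxy to pentyloxy.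

For the measured compounds named here, one measured step bears on this change. It is a 1.3-fold higher number from compound 1 to compound 2 (0.13 log units; within the scatter), with vinyl in place of 4-isopropylphenyl at the same place. That step stays within the scatter, although the group exchanged there includes a whole ring. Going by the values given here, no measured compound carries a plain butyl at this place, so the evidence is thin. No step beyond the scatter is expected in this assay, and neither direction is favoured with any confidence.

The estimated step is a 1.2-fold lower number from compound 2 to compound 3 (0.10 log units; within the scatter).

For compound 3 the expected value is 31000 nM, with an estimated range of 15000 nM to 62000 nM.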

Compound 3, half-maximal inhibitory concentration: 39300 nM
Estimate against measurement, compound 3: 1.3-fold (0.10 log units) below; low and high end bracket the measured number.
By their numbers in this assay, from the lowest: compounds 1, 2 and 3 (each within the scatter of the next).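

In this assay, butyl in place of vinyl on a saturated chain carbon bound to an oxygen on an aromatic ring gives a 1.0-fold higher number from compound 2 to compound 3 (0.01 log units; within the scatter), so this change, which adds two carbons and removes the double bond outside aromatic rings, leaves the read-out within the scatter. Butyl in place of 4-isopropylphenyl at the same place gives a 1.4-fold higher number from compound 1 to compound 3 (0.14 log units; within the scatter), which means that the open chain without a ring also cannot be separated from the ring-bearing group. All three pairs among compound 1, compound 2 and compound 3 now lie within the scatter, so this assay separates none of these three groups at this place, and no supporting measurement is available to account for that.

Going by these compounds, it remains open whether an amine or a carboxylic acid at the end of the chain, or a chain much longer than pentyl, would give a step beyond the scatter. On these data alone, it is also open whether a bare hydroxyl, with no chain on that oxygen, would read differently from the three ethers, and whether changes elsewhere on the shared core would shift the values more than changes at this place.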